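Swapping a Ring-Bearing Side Chain for a Hydroxybutyl Chain

This account rests on a few compounds, and the source may have more. Where it says the series, first, only, none or still open, it means among the compounds named here.

Measured compounds:
Compound 1, `C=CCn1c(=O)n([C@H]2CO[C@@H](CO)C2)c2nc(N)nc(O)c21`: 16%
Compound 2, `COc1ccc(Cn2c(=O)n(C3OC(CO)[C@@H](O)[C@H]3O)c3nc(N)nc(O)c32)cc1`: 14%
Compound 3, `Nc1nc(O)c2c(n1)n(C1OC(CO)[C@@H](O)[C@H]1O)c(=O)n2CCN1CCCCC1`: 0%

All three share one core and were tested in a functional assay on the whole organism with Mus musculus as the target; on this read-out lower numbers stand for smaller maximal responses and higher numbers for larger maximal responses. Compound 1 gives the largest number of the three, yet compound 2 sits within the usual scatter of it, so the two cannot be separated. Compound 3, with its value of 0%, lies well below compound 1, a gap beyond the scatter. Going by the values given here, the only step between two compounds that differ in a single place is a number 14 percentage points lower from compound 2 to compound 3 (beyond the scatter); it concerns the group on a saturated chain carbon bound to an aromatic nitrogen, not the side chain examined here.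

Compound 4, `C=CCn1c(=O)n(CCCCO)c2nc(N)nc(O)c21`, has not yet been measured. It differs from compound 1 as follows: a group of 5 heavy atoms (4 carbon, 1 oxygen; no ring) in place of a group of 7 heavy atoms (5 carbon, 2 oxygen; one five-membered non-aromatic ring with 1 hetero atom), on an aromatic nitrogen. Among the compounds with values here, no measured step touches this aromatic nitrogen. Within the data shown here, nothing among the measured compounds indicates a direction for this change. The expectation rests on the value of compound 1, 16%, and on that of compound 2, 14%, which lie within the scatter of each other. The expected step is therefore a number 2 percentage points lower from compound 1 to compound 4 (within the scatter), small and within the scatter. Compound 4 is estimated to reach 14% in this assay, with a range from 2% to 28%.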

Compound 4, largest response reached (reported as maximal response), in percent of the reference or control that the assay uses: 16%
Beside the measured number, compound 4's estimate is 2 percentage points below it; measured number inside the range.
By their numbers in this assay, from the lowest: compound 3; then compounds 2, 1 and 4 (each within the scatter of the next).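

In this assay, replacing the ring-bearing side chain on the aromatic nitrogen of compound 1 with a 4-hydroxybutyl chain gives no change at the digits printed from compound 1 to compound 4 (within the scatter). This is the only step shown at this position, and it indicates that, with the allyl group kept, the five-membered non-aromatic ring and its defined stereocentres can be exchanged for an open chain without moving the number in this assay beyond the scatter. No accompanying data on the compounds bear on why the number stays in place.

Because only this one replacement is shown at this nitrogen, it remains open whether a shorter chain, a longer chain, or a chain ending in an amine or a carboxylic acid would also leave the number in this assay in place. As far as these compounds go, it also remains open whether the hydroxyl at the end of the 4-hydroxybutyl chain matters, a question that a plain butyl chain on the same nitrogen could address by direct comparison with compound 4.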